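Swapping the Acyl Aryl Group in a Weakly Active Series

The source may hold more compounds than are shown below. What is called first, only, known or untested is meant among the compounds shown, and "the series" means these compounds.

Compound 1, `NC(=O)c1c(NC(=O)c2cccc([N+](=O)[O-])c2)sc2c1CCN(Cc1c(Cl)cccc1Cl)C2`, gives 46100 nM in a functional assay on HeLa cells (Homo sapiens) for antiproliferative activity, with a stated time of 24 h; a higher number here means a weaker inhibitor, a lower number a stronger inhibitor.
Compound 2, `NC(=O)c1c(NC(=O)c2ccccc2F)sc2c1CCN(C(=O)Nc1ccccc1Cl)C2`, reaches only the assay limit of > 50000 nM in this assay.
Compound 3, `NC(=O)c1c(NC(=O)c2ccc(C(F)(F)F)cc2)sc2c1CCN(C(=O)Nc1ccccc1Cl)C2`, likewise reaches only the assay limit of > 50000 nM in this assay.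

Compound 3 therefore stands at the weak end of what this assay can report (the limit of > 50000 nM in this assay, at which 2 of the 3 values shown sit). Compound 4, `NC(=O)c1c(NC(=O)c2cccc([N+](=O)[O-])c2)sc2c1CCN(C(=O)Nc1ccccc1Cl)C2`, differs from compound 3 in one place: 3-nitrophenyl in place of 4-(trifluoromethyl)phenyl on a carbonyl carbon. Within the data shown here, the only measured step that alters the same group, a step that the two limits leave unreadable from compound 2 to compound 3, cannot be read, and compound 1, which carries the same 3-nitrophenyl on a differently substituted core, is also weak. A step no larger than the scatter is therefore expected, a number no higher from compound 3 to compound 4 (the limit leaves the size open). Compound 4 is estimated at 50000 nM, between 25000 nM and 150000 nM, quite possibly again only as a limit.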

Compound 4, half-maximal inhibitory concentration: > 50000 nM
Compound 4: only a limit was reported; the forecaster's own chance of this, stated with the estimate: 60%; the middle value sits exactly at the limit.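

With (2-chlorophenyl)carbamoyl on the amine nitrogen in a ring, 3-nitrophenyl on the carbonyl carbon now joins 2-fluorophenyl and 4-(trifluoromethyl)phenyl at one limit in this assay: the limit of > 50000 nM in this assay, at which 3 of the 4 values shown sit. The steps among compound 2, compound 3 and compound 4 cannot be read. With 3-nitrophenyl held constant, (2-chlorophenyl)carbamoyl in place of 2,6-dichlorobenzyl gives an at least 1.0-fold higher number from compound 1 to compound 4 (0.03 log units; that floor lies within the scatter), so this change brings no measurable gain in strength.

From the compounds shown here alone, it remains open whether any aryl group at this position can give a readable value on the urea-bearing core. An amine or a carboxylic acid on that phenyl ring could show this.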